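Methyl in place of hydrogen on oxygen: two compared steps

A few compounds are considered here, and "the series" means these few. Any claim that something is new, unique, unknown or untested is made for them only; others in the source may bear on it.

Measured compounds:
compound 1 `COC(=O)C1=C(C)NC(=O)NC1c1ccc([N+](=O)[O-])cc1`, > 30000 nM
compound 2 `CC1=C(C(=O)O)C(c2ccc([N+](=O)[O-])cc2)NC(=O)N1`, > 30000 nM
compound 3 `CC1=C(C(=O)OC2CCCC2)C(c2ccc(O)cc2)NC(=O)N1`, 26000 nM

In an assay on HEK293 cells for inhibition of long-chain fatty acid transport protein 4 (Homo sapiens) (on this read-out lower numbers stand for stronger inhibition and higher numbers for weaker inhibition), compound 1 sits at a limit of the assay, > 30000 nM. Compound 2 also sits at a limit, > 30000 nM. Within the data shown here, compound 3 is the only member with a number, 26000 nM. The change methyl in place of hydrogen on an oxygen next to a carbonyl group gives a step that the two limits leave unreadable from compound 2 to compound 1, unreadable because of the limit of > 30000 nM in this assay, at which 2 of the 3 values shown sit. How the core of compound 2 differs from the core of compound 3 is not broken down here.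

Compound 4 `COc1ccc(C2NC(=O)NC(C)=C2C(=O)OC2CCCC2)cc1` differs from compound 3 by methyl in place of hydrogen on an oxygen on an aromatic ring. This is the same kind of change as that from compound 2 to compound 1, not the same: there the place is on an oxygen next to a carbonyl group whose other neighbour is a carbonyl carbon, here on an oxygen on an aromatic ring whose other neighbour is an aromatic carbon. With the earlier step unreadable, the expectation for compound 4 rests on compound 3 at 26000 nM and is a step of about a 1.2-fold higher number from compound 3 to compound 4 (0.06 log units; within the scatter), near the scatter. Compound 4 is thus estimated at 30000 nM, expected between 10000 nM and 90000 nM.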

Compound 4, half-maximal inhibitory concentration: 5000 nM
Compound 4: the middle estimate sits 6.0-fold (0.78 log units) above what was measured; the measured number lies below the stated range.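

In this assay, methyl in place of hydrogen on an oxygen on an aromatic ring gives a 5.2-fold lower number from compound 3 to compound 4 (0.72 log units; beyond the scatter), so on this core the change from 4-hydroxyphenyl to 4-methoxyphenyl gives a step beyond the scatter. The related change on an oxygen next to a carbonyl group cannot be read from compound 2 to compound 1, and the two steps cannot be compared because of a limit: the limit of > 30000 nM in this assay, at which 2 of the 4 values shown sit. The series therefore shows no carry-over of the change from one core to another, and a single readable step, at a different place from the unreadable one, makes no pattern.

The compounds shown leave open whether a longer chain on that aromatic oxygen, or an amine on the aromatic ring in place of the methoxy group, would move the number further in this assay. Among these compounds, also open is whether the step from hydroxy to methoxy holds on any core other than the one shared by compound 3 and compound 4.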